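Iodo to phenyl on the core of compound 3

The compounds below may be only part of what the source reports. "The series", "measured", "known", "first", "only" and "open" are said of these compounds alone.

Compound 1 `Nc1nc(N)c2c(-c3ccsc3)cn([C@@H]3O[C@H](CO)[C@@H](O)[C@H]3O)c2n1` and compound 2 `Nc1nc(N)c2c(-c3cc4ccccc4o3)cn([C@@H]3O[C@H](CO)[C@@H](O)[C@H]3O)c2n1` share one core; compound 3 `COc1ncnc2c1c(I)cn2[C@@H]1O[C@H](CO)[C@@H](O)[C@H]1O` and the still unmeasured compound 4 `COc1ncnc2c1c(-c1ccccc1)cn2[C@@H]1O[C@H](CO)[C@@H](O)[C@H]1O` share another. In a functional assay on HL-60 cells (Homo sapiens) for antiproliferative activity, read by XTT assay, with a stated time of 72 h (a lower number here means a stronger inhibitor, a higher number a weaker inhibitor), compound 1 gives > 20000 nM, which is a limit of the assay and not a number. Compound 2 gives > 15000 nM in this assay, likewise a limit. The step that the two limits leave unreadable from compound 1 to compound 2 therefore cannot be read in either size or direction. For the measured compounds named here, compound 3 gives 2300 nM in this assay, the only number among the three values shown. Compound 4 differs from compound 3 by phenyl in place of iodo on an aromatic carbon. No measured step covers this exchange: the single step shown lies on the other core and is itself unreadable, so nothing shown fixes the size or direction of the change in this assay. Compound 4 is therefore estimated at 5000 nM, with a range of 1200 nM to 20000 nM, which means an expected step of a 2.2-fold higher number from compound 3 to compound 4 (0.34 log units; beyond the scatter) that may well lie within the scatter. A reported limit for compound 4 would not be surprising.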

Compound 4, half-maximal inhibitory concentration: > 20000 nM
Compound 4: only a limit was reported (the forecaster's own chance of this, stated with the estimate: 30%); middle value at least 4.0-fold (0.60 log units) from the limit.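

On the core of compound 3, this aromatic carbon of the five-membered ring does not tolerate every exchange in this assay: phenyl in place of iodo gives an at least 8.6-fold higher number from compound 3 to compound 4 (0.93 log units; beyond the scatter). For the compounds shown here, this is the first readable step, since the only earlier step, on the other core, cannot be read. Compound 4 stands at a limit of the assay and not at a number: the limit of > 20000 nM in this assay, at which 2 of the 4 values shown sit.

The step therefore has a lower bound only, and the compounds shown do not fix how far compound 4 lies past that limit. Also open, as far as these compounds go, is how a methyl group, a chloro group or an amine on this same aromatic carbon would read in this assay, and whether iodo or the single ring of phenyl sets the result.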